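The source may report more compounds than this note shows. Statements on the series, on what has been measured and on what is new or still open speak of the compounds shown alone.

Measured in a functional assay on A-431 cells (Homo sapiens) for inhibition, read by sulforhodamine B assay, with a stated time of 2 days; a lower number here means a stronger inhibitor of growth, a higher number a weaker inhibitor of growth:
- compound 1 `N#Cc1cc2c(N)ncnc2nc1Nc1ccc(S(N)(=O)=O)cc1`: 7800 nM
- compound 2 `Cc1c(C#N)c(Nc2ccc(S(N)(=O)=O)cc2)nc2ncnc(N)c12`: 2940 nM

Compound 2, at 2940 nM, holds the lower of these two numbers in this assay. Compound 3 `Cc1c(C#N)c(Nc2ccc(S(N)(=O)=O)cc2)nc2nc(NCCO)nc(N)c12` brings one change: (2-hydroxyethyl)amino in place of hydrogen on an aromatic carbon, with (2-hydroxyethyl)amino in place of hydrogen on an aromatic carbon, between two ring nitrogen atoms. For the measured compounds named here, only one measured step exists, a 2.7-fold lower number from compound 1 to compound 2 (0.42 log units; beyond the scatter), and it concerns a methyl at a different place, so it gives only a rough sense of size. Going by the values given here, no measured compound carries this new group, so the direction stays open. The expected step is small, a 1.2-fold lower number from compound 2 to compound 3 (0.07 log units; within the scatter). Compound 3 is estimated at 2500 nM, with an expected range of 600 nM to 9000 nM.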

Compound 3, concentration for 50% growth inhibition: > 100000 nM
Compound 3 ended at the assay's limit (the forecaster's own chance of this, stated with the estimate: 10%); middle value at least 40-fold (1.60 log units) from the limit.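

In this assay, placing (2-hydroxyethyl)amino on the aromatic carbon between two ring nitrogen atoms brings an at least 34-fold higher number from compound 2 to compound 3 (1.53 log units; beyond the scatter), so growth inhibition is strongly sensitive to this change. For the compounds shown here, the only earlier step, a 2.7-fold lower number from compound 1 to compound 2 (0.42 log units; beyond the scatter), concerned a methyl at a different place and said nothing about this position. Compound 3 stands at a limit of the assay, not at a number: the limit of > 100000 nM in this assay, at which 1 of the 3 values shown sits.

Still open, on these data alone, is whether a plain amino group or a methyl on this carbon would cost as much. A methoxy group would show whether the loss also occurs without the chain's amine nitrogen.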